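Swapping a Benzyl for Isopropyl on a Chemokine Receptor Ligand

A few compounds are considered here, and "the series" means these few. Any claim that something is new, unique, unknown or untested is made for them only; others in the source may bear on it.

Compound 1 `CC(C)CCC(=O)N[C@@H](C(=O)N1CCC(c2ccc(Cl)cc2)CC1)C(C)C`, compound 2 `CC(C)[C@@H](NC(=O)CCCc1ccccc1)C(=O)N1CCC(c2ccc(Cl)cc2)CC1` and compound 3 `CC[C@@H](C)[C@@H](NC(=O)CCc1ccccc1)C(=O)N1CCC(c2ccc(Cl)cc2)CC1` were tested in an assay on THP-1 cells for displacement of a labelled ligand from C-C chemokine receptor type 1 (Homo sapiens); a lower number here means a stronger inhibitor, a higher number a weaker inhibitor. There compound 1 gives 26 nM, compound 2 gives 95 nM and compound 3 gives 66 nM. From compound 2 to compound 1 the change is isopropyl in place of benzyl on a saturated chain carbon, two bonds along the chain from a carbonyl carbon, and it made a 3.7-fold lower number from compound 2 to compound 1 (0.56 log units; beyond the scatter). Compound 4 `CC[C@@H](C)[C@@H](NC(=O)CC(C)C)C(=O)N1CCC(c2ccc(Cl)cc2)CC1`, not yet measured, arises from compound 3 by isopropyl in place of benzyl on a saturated chain carbon bound to a carbonyl carbon. This is the same kind of change, but the place differs: earlier the carbon was two bonds along the chain from a carbonyl carbon, here it is bound to a carbonyl carbon. The difference between the cores of compound 3 and compound 2 is not broken down here. A similar drop is expected, a 2.6-fold lower number from compound 3 to compound 4 (0.42 log units; beyond the scatter), because the earlier pair showed a 3.7-fold lower number from compound 2 to compound 1 (0.56 log units; beyond the scatter). Compound 4 is estimated at 25 nM, between 10 nM and 60 nM.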

Compound 4, half-maximal inhibitory concentration: 34 nM
Compound 4: the middle estimate sits 1.4-fold (0.13 log units) below what was measured; the range from low to high includes it.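

In this assay isopropyl in place of benzyl gives a 1.9-fold lower number from compound 3 to compound 4 (0.29 log units; within the scatter) and so, on this core, the change cannot be told apart from the ordinary spread of repeated measurements. Set beside the earlier step, the result on this core does not differ measurably from the first: the same change on two cores in this assay, a 3.7-fold lower number (0.56 log units; beyond the scatter) from compound 2 to compound 1 and a 1.9-fold lower number (0.29 log units; within the scatter) from compound 3 to compound 4, 1.9-fold (0.27 log units) apart, within the scatter of two such steps. This agreement fits the change carrying over, but two pairs, one of them within the scatter and with the change at a different place on the chain, do not prove that it transfers reliably across the series, nor do they explain why it might.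

Still open, going by these compounds, is how other groups at this place, such as an amine or a longer chain, would compare with isopropyl and benzyl. Also open, on these data alone, is whether the change would hold on a core other than these two.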